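Fluoro in Place of Chloro: What Compound 3 May Show

A few compounds are considered here, and "the series" means these few. Any claim that something is new, unique, unknown or untested is made for them only; others in the source may bear on it.

Measured so far:
compound 1, `Cc1cc(-c2nc3cc(F)ccc3o2)ccc1NC(=O)CN1CCN(CCN(C)C)CC1`, in an ADME assay on NIH3T3 cells (Mus musculus) for cytotoxicity, read by MTT assay, with a stated time of 24 h (on this read-out higher numbers stand for weaker inhibition and lower numbers for stronger inhibition), compound 1 gives 62100 nM
compound 2, `Cc1cc(-c2nc3cc(Cl)ccc3o2)ccc1NC(=O)CCl`, in this assay compound 2 gives 8640 nM

Among the compounds with values here, compound 2 stands at the lowest of the two numbers in this assay; the only other value, that of compound 1, lies higher by a gap beyond the usual scatter. The two compounds differ in more than one place, so their pair says nothing by itself about any single change.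

Within the data shown here, compound 3, `Cc1cc(-c2nc3cc(F)ccc3o2)ccc1NC(=O)CCl`, is the one compound not yet measured. Its structure differs from compound 2 in one place: fluoro in place of chloro on an aromatic carbon. The rest of the molecule, including the amide side chain, is the same as in compound 2.

Among the measured compounds shown here, no pair of measured compounds isolates this change, so the expectation rests on compound 2 alone. A swap of one halogen for another at this position is expected to move the number in this assay little, if at all, and any shift is expected to stay within the scatter. Compound 3 is therefore estimated at 12000 nM, with a range from 5000 nM to 30000 nM, which means an expected step of a 1.4-fold higher number from compound 2 to compound 3 (0.14 log units; within the scatter).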

Compound 3, half-maximal inhibitory concentration: 10500 nM
Compound 3: middle estimate off by 1.1-fold (0.06 log units), on the high side; the measured number falls inside the stated range.
By their numbers in this assay, from the lowest: compounds 2 and 3 (each within the scatter of the next); then compound 1.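

In this assay, within the data shown here, fluoro in place of chloro on an aromatic carbon gives a 1.2-fold higher number from compound 2 to compound 3 (0.08 log units; within the scatter), the first step here that isolates a single change, and it lies within the scatter. At this position, then, the two halogens cannot be told apart in this read-out, and compound 2 and compound 3 sit together at the low end of the series. Among these compounds, with fluoro now shared, compound 1 and compound 3 differ only in the amide side chain, and the printed values, compound 3 at 10500 nM and compound 1 at 62100 nM, lie beyond the scatter of each other, although no single pair yet shows which part of that side chain matters. No evidence given here explains why the halogen swap has so small a step.

Going by these compounds, it remains open whether an amine or a methoxy group on this aromatic carbon would stay as close to compound 2 as fluoro does. On these data alone, it is equally open whether chloro and fluoro would still match when the amide side chain is the longer amine chain of compound 1, or a simple acetyl group without the chloro.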